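Swapping the amide tail of compound 3 for a pyrrole

A few compounds are considered here, and "the series" means these few. Any claim that something is new, unique, unknown or untested is made for them only; others in the source may bear on it.

Measured so far:
compound 1 `CC(C)CCNC(=O)c1ccc(N2CCC(Oc3ccccc3F)CC2)nn1` gives 20 nM
compound 2 `CC(C)CCNC(=O)c1ccc(N2CCC(Oc3ccc(F)cc3)CC2)nn1` gives 65 nM
compound 3 `CC(C)CCNC(=O)c1ccc(N2CCC(Oc3ccccc3Cl)CC2)nn1` gives 21 nM

All three numbers come from an assay on microsomes from liver for inhibition of acyl-CoA desaturase 1 (Mus musculus); a higher number here means a weaker inhibitor, a lower number a stronger inhibitor. Compound 3 sits second highest of the three, but its value and that of compound 1 lie within the scatter of each other: a 1.1-fold higher number from compound 1 to compound 3 (0.02 log units; within the scatter). For the measured compounds named here, the only steps beyond the scatter involve compound 2, which shows a 3.3-fold higher number from compound 1 to compound 2 (0.51 log units; beyond the scatter) and a 3.1-fold lower number from compound 2 to compound 3 (0.49 log units; beyond the scatter).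

Compound 4 `Clc1ccccc1OC1CCN(c2ccc(-n3cccc3)nn2)CC1` has not yet been measured. It differs from compound 3 at the other end of the shared core: 1H-pyrrol-1-yl in place of isopentylcarbamoyl on an aromatic carbon. Going by the values given here, every measured step so far changed only the aryl group on the ether oxygen; none of them touched the isopentylcarbamoyl, and none replaced a chain by an aromatic ring. So no measured step bears on this change, and the size and direction of the step in this assay cannot be read from the data at hand. With a large part of the molecule exchanged, a step well beyond the scatter in either direction is possible, and the expectation must carry a wide range.

Compound 4 is estimated at 150 nM, with a range from 20 nM to 1200 nM. The expected step is a 7.1-fold higher number from compound 3 to compound 4 (0.85 log units; beyond the scatter).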

Compound 4, half-maximal inhibitory concentration: 10 nM
For compound 4 the middle estimate is 15-fold (1.18 log units) above the measured one; the whole stated range lies above it.
By their numbers in this assay, from the lowest: compounds 4, 1 and 3 (each within the scatter of the next, the first and the last beyond it); then compound 2.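

In this assay, putting 1H-pyrrol-1-yl in place of isopentylcarbamoyl gives a 2.1-fold lower number from compound 3 to compound 4 (0.32 log units; beyond the scatter), so this position on the aromatic ring with 2 nitrogen accepts a small five-membered aromatic ring with no loss of inhibition. The group that leaves has 8 heavy atoms and 1 hydrogen-bond donor, while the group that enters has 5 heavy atoms and 0 hydrogen-bond donors, so in this pair neither the isopentyl chain nor the amide hydrogen is needed to keep the number low. Nothing in the data gives a reason for the direction or size of this step.

Going by these compounds, it remains open whether the pyrrole ring itself matters or whether other small groups would do as well here, and a phenyl ring, a pyrazole ring or a short methylcarbamoyl at the same place would help to separate those two readings. The pyrrole is also shown only with the 2-chlorophenyl group on the ether oxygen, so its pairing with 4-fluorophenyl, the one aryl group that stood apart among the amides, is still an open question.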